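This account rests on a few compounds, and the source may have more. Where it says the series, first, only, none or still open, it means among the compounds named here.

In an in vitro functional assay on cells (Fibroblast) for agonist activity at Alpha-1A adrenergic receptor (Homo sapiens) (on this read-out lower numbers stand for an effect already at smaller amounts and higher numbers for an effect only at larger amounts of compound), compound 2 `Cn1nccc1-c1ccccc1NCC1=NCCN1` gives 10 nM, the lowest of the two numbers reported so far. Its nearest neighbour is compound 1 `CCCn1ncnc1-c1ccccc1NCC1=NCCN1`, which in this assay gives 12.6 nM, a gap that lies within the scatter of repeated measurements. Compound 3 `CC(C)n1nccc1-c1ccccc1NCC1=NCCN1` is reported in this assay only as a limit, < 100000 nM. Among the measured compounds shown here, the single measured step between neighbours, a step that the limit leaves unreadable from compound 2 to compound 3, cannot be given a size because the limit of < 100000 nM in this assay, at which 1 of the 3 values shown sits, hides how far it went.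

The step now followed leads from compound 2 to compound 4 `Cn1ccc(-c2ccccc2NCC2=NCCN2)n1`. The change is 1-methyl-1H-pyrazol-3-yl in place of 1-methyl-1H-pyrazol-5-yl on an aromatic carbon. For the measured compounds named here, no measured step touches this kind of rearrangement, and the one step that exists is unreadable, so nothing in the data points to a direction. Compound 4 is therefore expected to stay near compound 2, with an estimated step of a 3.0-fold higher number from compound 2 to compound 4 (0.48 log units; beyond the scatter) in this assay. For compound 4 the estimate in this assay is 30 nM, in a range from 5 nM to 300 nM.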

Compound 4, half-maximal effective concentration: 3.16 nM
For compound 4 the middle estimate is 9.5-fold (0.98 log units) above the measured one, outside the stated range (below it).
By their numbers in this assay, from the lowest: compound 4; then compounds 2 and 1 (each within the scatter of the next).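

Exchanging 1-methyl-1H-pyrazol-5-yl for 1-methyl-1H-pyrazol-3-yl on the aromatic carbon gives the first readable step from compound 2 in this assay: a 3.2-fold lower number from compound 2 to compound 4 (0.50 log units; beyond the scatter). Among the compounds shown here, the two groups have the same atoms and the same counts of hydrogen-bond donors and acceptors, yet joining them differently is enough to move the number beyond the scatter, which the earlier compounds could not show. The other step from compound 2, to compound 3, cannot be read: the limit of < 100000 nM in this assay, at which 1 of the 4 values shown sits.

The compounds shown leave open whether compound 4 would keep its number with isopropyl or a longer chain in place of methyl on its aromatic nitrogen. They also do not tell how an ethyl group or an amine on this five-membered ring would behave in this assay.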